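Benzyl for Trifluoromethylphenyl on the Pyrazole Nitrogen: Cytotoxicity

A few compounds are considered here, and "the series" means these few. Any claim that something is new, unique, unknown or untested is made for them only; others in the source may bear on it.

Compound 1 `Cc1ccccc1-c1nn(-c2ccc(F)cc2F)cc1CNCCN1CCN(C)CC1` gives > 20000 nM in an ADME assay on Huh-7 cells (Homo sapiens) for cytotoxicity; a lower number here means that less compound is tolerated, a higher number that more compound is tolerated; compound 2 `Cc1ccccc1-c1nn(-c2ccc(C(F)(F)F)cc2)cc1CNCCN1CCN(C)CC1` gives 11000 nM in this assay.

The value of compound 1 is a limit of the assay, not a number, and the limit is the limit of > 20000 nM in this assay, at which 1 of the 2 values shown sits. Compound 2 holds the only number shown. Among the compounds with values here, the step of an at least 1.8-fold lower number from compound 1 to compound 2 (0.25 log units; that floor lies within the scatter) is the single measured step and it lies within the scatter. Compound 3 `Cc1ccccc1-c1nn(Cc2ccccc2)cc1CNCCN1CCN(C)CC1` differs from compound 2 by benzyl in place of 4-(trifluoromethyl)phenyl on an aromatic nitrogen. Within the data shown here, no measured step shows a benzyl on that nitrogen, so only a step within the scatter is expected: a 1.4-fold higher number from compound 2 to compound 3 (0.13 log units; within the scatter). Compound 3 is estimated at 15000 nM, between 6000 nM and 40000 nM.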

Compound 3, half-maximal cytotoxic concentration: > 20000 nM
Compound 3 gave a limit, no number; the forecaster's own chance of this, stated with the estimate: 40%; middle value at least 1.3-fold (0.12 log units) from the limit.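

Benzyl on the pyrazole nitrogen gives an at least 1.8-fold higher number from compound 2 to compound 3 (0.25 log units; that floor lies within the scatter), so a benzyl in place of 4-(trifluoromethyl)phenyl also leaves no step shown to be beyond the scatter. The value of compound 3 is a limit and not a number, and the step between compound 1 and compound 3 cannot be read. The limit now holds most of the series, so the values shown give little resolution at this position: the limit of > 20000 nM in this assay, at which 2 of the 3 values shown sit.

Open remains how a phenethyl group or a carboxylic acid on that nitrogen would read in this assay.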